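Chloro for bromo, measured once and expected a second time

A few compounds are considered here, and "the series" means these few. Any claim that something is new, unique, unknown or untested is made for them only; others in the source may bear on it.

Compound 1 `CC1(C)CC(NC(=O)NCc2ccccc2)c2cc(Br)ccc2O1`: 38000 nM
Compound 2 `CC1(C)CC(NC(=O)NCc2ccccc2)c2cc(Cl)ccc2O1`: 15000 nM
Compound 3 `CC1(C)CC(NC(=S)NCc2ccccc2)c2cc(Br)ccc2O1`: 54000 nM

All three were tested in a functional assay on T98G cells (Homo sapiens) for inhibition, read by MTT assay, with a stated time of 72 h; on this read-out lower numbers stand for stronger inhibition and higher numbers for weaker inhibition. Between compound 1 and compound 2 the only change is chloro in place of bromo on an aromatic carbon, and it gave a 2.5-fold lower number from compound 1 to compound 2 (0.40 log units; beyond the scatter). Compound 3 shares with compound 1 the bromo group but differs elsewhere; the difference between the two cores is not broken down here. Compound 3 stands within the scatter of compound 1 and beyond it from compound 2.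

Compound 4 `CC1(C)CC(NC(=S)NCc2ccccc2)c2cc(Cl)ccc2O1` has not been measured. It differs from compound 3 by chloro in place of bromo on an aromatic carbon, the same change as from compound 1 to compound 2, made at the same place. Resting on that earlier step, and on compound 3 at 54000 nM, the expected step in this assay is a 2.5-fold lower number from compound 3 to compound 4 (0.39 log units; beyond the scatter). Compound 4 is therefore estimated at 22000 nM, with a plausible span from 10000 nM to 50000 nM.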

Compound 4, half-maximal inhibitory concentration: 99000 nM
For compound 4 the middle estimate is 4.5-fold (0.65 log units) below the measured one; the whole stated range lies below it.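

In this assay, chloro in place of bromo gave a 1.8-fold higher number from compound 3 to compound 4 (0.26 log units; within the scatter), so on this core the change has no clear effect, whereas on the core of compound 1 it had one. The step therefore did not carry over from one core to the other: the same change on two cores in this assay, a 2.5-fold lower number (0.40 log units; beyond the scatter) from compound 1 to compound 2 and a 1.8-fold higher number (0.26 log units; within the scatter) from compound 3 to compound 4, 4.6-fold (0.67 log units) apart, beyond the scatter of two such steps. For the compounds shown here, this rests on a single pair for each core, so it shows only that the step cannot be assumed to transfer between these two cores; it does not show why the two differ or how the change would behave on any other core.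

The compounds shown carry only bromo or chloro at this aromatic carbon, so the effect of a fluoro, a methoxy or an amine there remains open. Also open, going by these compounds, is whether any such group would give steps that agree across the two cores.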